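Iodo in Place of Bromo on the Shared Core

The compounds below may be only part of what the source reports. "The series", "measured", "known", "first", "only" and "open" are said of these compounds alone.

Compound 1, `CCOC(=O)c1ccc(NC(=O)N[C@@H](C)c2ccccc2)cc1`: 97%
Compound 2, `C[C@H](NC(=O)Nc1ccc(Br)cc1)c1ccccc1`: 97%

In an ADME assay on the whole organism with Oryza sativa as the target, tested at 1 uM (on this read-out higher numbers stand for a weaker effect at the one concentration tested and lower numbers for a stronger effect), compound 1 gives 97%. In this assay compound 2 gives 97%. The only measured step, no change at the digits printed from compound 1 to compound 2 (within the scatter), stayed within the scatter, so compound 2 stands level with compound 1 at the digits shown. Compound 3, `C[C@H](NC(=O)Nc1ccc(I)cc1)c1ccccc1`, differs from compound 2 in one place: iodo in place of bromo on an aromatic carbon. Among the compounds with values here, the only step that bears on this, from compound 1 to compound 2, was within the scatter, so no shift beyond the scatter is expected in this assay. Compound 3 is therefore estimated at 96%, between 86% and 100%, an expected step of a number 1 percentage points lower from compound 2 to compound 3 (within the scatter).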

Compound 3, a percentage reported as activity, at one concentration (the size of the read-out at that concentration, not a potency): 97%
Estimate against measurement, compound 3: 1 percentage points below; measured number inside the range.
By their numbers in this assay, from the lowest: compounds 1, 2 and 3 (each within the scatter of the next).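

In this assay the iodo group in place of bromo leaves the read-out flat (no change at the digits printed from compound 2 to compound 3 (within the scatter)), and iodo in place of ethoxycarbonyl does the same (no change at the digits printed from compound 1 to compound 3 (within the scatter)). At this aromatic carbon, para to a large group, three different groups now read alike, two of them halogens. No evidence is available to explain this result. As far as these compounds go, whether an amine, a carboxylic acid or a longer chain at this place would move the number beyond the scatter stays open.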